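Chloro for Trifluoromethyl on the Methoxy Analogue

This account rests on a few compounds, and the source may have more. Where it says the series, first, only, none or still open, it means among the compounds named here.

Measured compounds in a functional assay on PC-3 cells (Homo sapiens) for inhibition, read by sulforhodamine B assay, with a stated time of 48 h, tested at 10 uM; a higher number here means a weaker effect of the compound at the concentration tested, a lower number a stronger effect:
compound 1, `O=C(Nc1cccc(-n2cc(-c3ccncc3)c(-c3cc(O)cc(Cl)c3)n2)c1)Nc1ccc(Cl)c(C(F)(F)F)c1`, 5.34%
compound 2, `O=C(Nc1cccc(-n2cc(-c3ccncc3)c(-c3cc(O)cc(Cl)c3)n2)c1)Nc1ccc(Cl)c(Cl)c1`, -1.66%
compound 3, `COc1cc(Cl)cc(-c2nn(-c3cccc(NC(=O)Nc4ccc(Cl)c(C(F)(F)F)c4)c3)cc2-c2ccncc2)c1`, -13%

Compound 2 differs from compound 1 by chloro in place of trifluoromethyl on an aromatic carbon, and in this assay the step is a number 7 percentage points lower from compound 1 to compound 2 (within the scatter). Compound 3 differs from compound 1 by methyl in place of hydrogen on an oxygen on an aromatic ring, and here the step is a number 18.3 percentage points lower from compound 1 to compound 3 (beyond the scatter), leaving compound 3 with the lowest number of the three.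

Compound 4, `COc1cc(Cl)cc(-c2nn(-c3cccc(NC(=O)Nc4ccc(Cl)c(Cl)c4)c3)cc2-c2ccncc2)c1`, has not been measured. It differs from compound 3 by chloro in place of trifluoromethyl on an aromatic carbon, which is the same change that separates compound 1 from compound 2; the surroundings of the place are identical word for word, so the change is the same, not merely the same kind. For the measured compounds named here, the one earlier instance gave a step within the scatter, so a small step is expected from compound 3 to compound 4 as well, a number 5 percentage points lower from compound 3 to compound 4 (within the scatter), resting on the step of a number 7 percentage points lower from compound 1 to compound 2 (within the scatter). Compound 4 is therefore estimated at -18% in this assay, with the expected range from -32% to -4%.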

Compound 4, a percentage reported as activity, at one concentration (the size of the read-out at that concentration, not a potency): -5.03%
The estimate for compound 4 lay 13 percentage points below the measured number; measured number inside the range.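

Carried onto the core of compound 3, chloro in place of trifluoromethyl gave a step of a number 8 percentage points higher from compound 3 to compound 4 (within the scatter) in this assay, so each step alone is small, yet the two instances do not agree: the same change on two cores in this assay, a number 7 percentage points lower (within the scatter) from compound 1 to compound 2 and a number 8 percentage points higher (within the scatter) from compound 3 to compound 4, 15 percentage points apart, beyond the scatter of two such steps. Methyl in place of hydrogen on the oxygen, carried onto the core of compound 2, gave only a number 3.4 percentage points lower from compound 2 to compound 4 (within the scatter), far smaller than its first instance: the same change on two cores in this assay, a number 18.3 percentage points lower (beyond the scatter) from compound 1 to compound 3 and a number 3.4 percentage points lower (within the scatter) from compound 2 to compound 4, 15 percentage points apart, beyond the scatter of two such steps. Neither change therefore moved as a fixed increment across these cores, but both comparisons rest on the same four compounds, so they amount to one observation of the two changes failing to add up, and they show neither why that happens nor whether it extends to other cores.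

The compounds shown leave open how a longer chain, such as ethyl, would behave on that oxygen. They also leave open whether a nitrile or a methyl in the place held by trifluoromethyl and chloro would follow either step.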